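The compounds below may be only part of what the source reports. "The series", "measured", "known", "first", "only" and "open" are said of these compounds alone.

Compound 1 `O=C(NCC1CCCCC1)c1cccc(/C=C2\CC(=O)N(c3ccccc3)C2=O)c1` gives > 100000 nM in an ADME assay on HCT-116 cells (Homo sapiens) for cytotoxicity, read by MTT assay, with a stated time of 72 h (on this read-out higher numbers stand for weaker inhibition and lower numbers for stronger inhibition), which is a limit of the assay rather than a number.
Compound 2 `Cc1ccc(NC(=O)c2cccc(/C=C3\CC(=O)N(c4ccccc4)C3=O)c2)cc1C` gives > 100000 nM, again a limit of the assay.
Compound 3 `CCc1cccc(NC(=O)c2cccc(/C=C3\CC(=O)N(c4ccccc4)C3=O)c2)c1` gives 81200 nM.

Compound 3 therefore stands as the only one of the three with a measured number; the other two sit at the limit of > 100000 nM in this assay, at which 2 of the 3 values shown sit. The steps that reach it are small: an at least 1.2-fold lower number from compound 1 to compound 3 (0.09 log units; that floor lies within the scatter) and an at least 1.2-fold lower number from compound 2 to compound 3 (0.09 log units; that floor lies within the scatter), both only floors set by the limits, and both within the scatter. The step that the two limits leave unreadable from compound 1 to compound 2 cannot be read at all. In short, changing the group on the amide-type nitrogen from cyclohexylmethyl or 3,4-dimethylphenyl to 3-ethylphenyl has not moved this assay beyond its noise.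

Compound 4 `O=C(Nc1ccccc1)c1cccc(/C=C2\CC(=O)N(c3ccccc3)C2=O)c1` is the next step from compound 3: hydrogen in place of ethyl on an aromatic carbon. This is a smaller trim than any of the measured changes, which themselves left this assay essentially flat. The expectation is therefore no step beyond the scatter, with a fair chance that the assay again returns only a limit.

Compound 4 is estimated at 100000 nM, between 40000 nM and 300000 nM, which means an expected step of a 1.2-fold higher number from compound 3 to compound 4 (0.09 log units; within the scatter).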

Compound 4, half-maximal inhibitory concentration: > 100000 nM
Compound 4 gave a limit, no number; the forecaster's own chance of this, stated with the estimate: 50%; the middle value lies on the limit itself.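

Among these compounds, replacing the ethyl of the 3-ethylphenyl group with hydrogen is the first change here that trims a single substituent on an aromatic carbon, rather than exchanging the whole group on the amide-type nitrogen, and in this assay it gives an at least 1.2-fold higher number from compound 3 to compound 4 (0.09 log units; that floor lies within the scatter). This step is only a floor set by a limit, so the data do not show whether the ethyl group matters at this position: the true step could be small or large. The steps from compound 1 and from compound 2 to compound 4 cannot be read, as both ends of each are limits, and most of the series now rests at a single ceiling: the limit of > 100000 nM in this assay, at which 3 of the 4 values shown sit.

Going by these compounds, it remains open whether any other group at this place on the ring, such as an amine, a carboxylic acid or a longer chain, would give a step beyond the scatter. Also open, on these data alone, is how far compound 1, compound 2 and compound 4 actually differ from one another, since their limits hide any true numbers.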